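The source may report more compounds than this note shows. Statements on the series, on what has been measured and on what is new or still open speak of the compounds shown alone.

Measured so far:
compound 1 `C/C1=C\CC[C@@]2(C)O[C@@H]2[C@H]2OC(=O)[C@@H](CN3CCN(C)CC3)[C@@H]2C[C@H]1O`: 25000 nM
compound 2 `C/C1=C\CC[C@@]2(C)O[C@@H]2[C@H]2OC(=O)[C@@H](CN3CCCCC3)[C@@H]2C[C@@H]1O`: 6000 nM

In a functional assay on B16-F10 cells (Mus musculus) for inhibition, read by colorimetric assay and MTT assay, with a stated time of 72 h (a higher number here means a weaker inhibitor, a lower number a stronger inhibitor), compound 2 gives 6000 nM, the lower of the two numbers. The gap up to compound 1 lies beyond the usual scatter of repeated measurements, so compound 2 is the stronger inhibitor of this pair, although two values are very little to go on.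

Compound 3 `C/C1=C\CC[C@@]2(C)O[C@@H]2[C@H]2OC(=O)[C@@H](CN3CCN(C)CC3)[C@@H]2C[C@@H]1O` differs from compound 2 in one place: 4-methylpiperazin-1-yl in place of piperidin-1-yl on a saturated chain carbon bound to a saturated ring carbon. The exchange sits on a saturated chain carbon bound to a saturated ring carbon.

Within the data shown here, no measured step isolates this change. Compound 1 also carries 4-methylpiperazin-1-yl and gives 25000 nM, which points to a moderate expected move toward a higher number, meaning a weaker inhibitor. This move may barely clear the scatter. The expected change is a 2.5-fold higher number from compound 2 to compound 3 (0.40 log units; beyond the scatter). For compound 3 the estimate is 15000 nM, with an expected range from 6000 nM to 35000 nM.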

Compound 3, half-maximal inhibitory concentration: 9000 nM
The estimate for compound 3 lay 1.7-fold (0.22 log units) above the measured number; the measured number falls inside the stated range.
By their numbers in this assay, from the lowest: compounds 2 and 3 (each within the scatter of the next); then compound 1.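

In this assay, placing 4-methylpiperazin-1-yl where piperidin-1-yl stood, on a saturated chain carbon bound to a saturated ring carbon, gives a 1.5-fold higher number from compound 2 to compound 3 (0.18 log units; within the scatter), so the data do not separate these two rings at this position. A clearer difference appears at a stereocentre on a saturated ring carbon, drawn R in compound 1 and S in compound 3, with a 2.8-fold lower number from compound 1 to compound 3 (0.44 log units; beyond the scatter), although this step is only modest. This step can be tied to that single stereocentre, since nothing else in the two structures changes: the fact that compounds 1 and 3 differ only in the configuration as drawn

As far as these compounds go, the stereocentre comparison is available only with 4-methylpiperazin-1-yl, so it remains open whether the same holds with piperidin-1-yl. From the compounds shown here alone, how other amines, such as morpholin-4-yl or an open-chain dimethylamino group, would behave at this place also remains open.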